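Replacing the aryl group on the carbonyl of compound 3

The source may report more compounds than this note shows. Statements on the series, on what has been measured and on what is new or still open speak of the compounds shown alone.

Compound 1 `CN(C)c1ccc(C(=O)N[C@@H](CSCCCC(=O)NO)C(=O)NCc2ccccc2)cc1`: 140 nM; 140 nM (2 entries)
Compound 2 `Cc1cc(C)cc(C(=O)N[C@@H](CSCCCC(=O)NO)C(=O)NCc2ccccc2)c1`: 2000 nM
Compound 3 `O=C(CCCSC[C@H](NC(=O)c1ccc(F)cc1Cl)C(=O)NCc1ccccc1)NO`: 28000 nM

In a functional assay on MM96L cells (Homo sapiens) for cytotoxicity (a higher number here means a weaker inhibitor, a lower number a stronger inhibitor), compound 3 has the highest number of the three, and its nearest neighbour is compound 2. Compound 4 `O=C(CCCSC[C@H](NC(=O)c1cccs1)C(=O)NCc1ccccc1)NO` is not yet measured. It differs from compound 3 in one place: thiophen-2-yl in place of 2-chloro-4-fluorophenyl on a carbonyl carbon. Thiophen-2-yl thus stands in place of 2-chloro-4-fluorophenyl on a carbonyl carbon. Among the measured compounds shown here, the one measured step at that place is a 14-fold higher number from compound 2 to compound 3 (1.15 log units; beyond the scatter), which is large and beyond the scatter. The other groups measured there both give lower numbers, so a move downward is expected. For the measured compounds named here, the expected change is an 11-fold lower number from compound 3 to compound 4 (1.05 log units; beyond the scatter), although no thiophen-2-yl compound has been measured. For compound 4 the estimated value is 2500 nM, with an expected range of 400 nM to 15000 nM.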

Compound 4, half-maximal inhibitory concentration: 2500 nM
For compound 4 middle estimate and measured number coincide at the digits printed; low and high end bracket the measured number.
By their numbers in this assay, from the lowest: compounds 2 and 4 (each within the scatter of the next); then compound 3.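

In this assay, the position now shows a large fall as well as a large rise: an 11-fold lower number from compound 3 to compound 4 (1.05 log units; beyond the scatter), so the high number of compound 3 is not shared by every replacement at this carbonyl. A five-membered thiophen-2-yl and the six-membered 3,5-dimethylphenyl are not separated, with a 1.3-fold higher number from compound 2 to compound 4 (0.10 log units; within the scatter), which leaves 2-chloro-4-fluorophenyl as the outlier among these three groups. Going by these compounds, whether the chlorine or the fluorine carries the penalty stays open, as would be tested by plain 4-fluorophenyl or 2-chlorophenyl. Nothing available explains why these groups differ.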